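Amide partner swap on a vitamin D receptor agonist core

The compounds below may be only part of what the source reports. "The series", "measured", "known", "first", "only" and "open" are said of these compounds alone.

Measured compounds:
- compound 1, `CC[C@@H](C)[C@H](NC(=O)c1ccc(C(CC)(CC)c2ccc(OCC(O)C(C)(C)C)c(C)c2)n1CC)C(=O)OC`, 26 nM
- compound 2, `CCn1c(C(=O)NCCN)ccc1C(CC)(CC)c1ccc(OCC(O)C(C)(C)C)c(C)c1`, 10 nM
- compound 3, `CCn1c(C(=O)N(C)c2ccccc2)ccc1C(CC)(CC)c1ccc(OCC(O)C(C)(C)C)c(C)c1`, 6400 nM

These values come from an assay on HL-60 cells for agonist activity at vitamin D3 receptor (Homo sapiens), read by microscopy, with a stated time of 96 h; on this read-out higher numbers stand for an effect only at larger amounts of compound and lower numbers for an effect already at smaller amounts. Compound 3 stands at the top of the three numbers: the step of a 250-fold higher number from compound 1 to compound 3 (2.39 log units; beyond the scatter) and the step of a 640-fold higher number from compound 2 to compound 3 (2.81 log units; beyond the scatter) are both large and both beyond the scatter, so compound 3 is the weakest of the three.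

Compound 4, `CC[C@@H](C)[C@H](NC(=O)c1ccc(C(CC)(CC)c2ccc(OCC(O)C(C)(C)C)c(C)c2)n1CC)C(=O)O`, has not yet been measured. It differs from compound 3 in one place: (1-carboxy-2-methylbutyl)amino in place of methyl(phenyl)amino on a carbonyl carbon. Among the measured compounds shown here, the entering group resembles the 1-(methoxycarbonyl)-2-methylbutyl group of compound 1, differing only in the carboxy in place of the methoxycarbonyl, a change for which no measured pair exists here. The two steps that bear on this move, a 250-fold higher number from compound 1 to compound 3 (2.39 log units; beyond the scatter) and a 640-fold higher number from compound 2 to compound 3 (2.81 log units; beyond the scatter), show that replacing an amine-bearing or ester-bearing alkylamino partner by methyl(phenyl)amino raised the number greatly; going the other way, a large drop is therefore expected, a 110-fold lower number from compound 3 to compound 4 (2.03 log units; beyond the scatter). Compound 4 is estimated at 60 nM, within 10 nM to 400 nM.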

Compound 4, half-maximal effective concentration: 2.3 nM
Estimate against measurement, compound 4: 26-fold (1.42 log units) above, outside the stated range (below it).
By their numbers in this assay, from the lowest: compound 4; then compound 2; then compound 1; then compound 3.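

Among the compounds shown here, the single change from ester to carboxylic acid gives an 11-fold lower number from compound 1 to compound 4 (1.05 log units; beyond the scatter) and so shows that this end of the amide partner matters on its own, a point the earlier compounds could not settle. The acid also improves on the amine-bearing partner, with a 4.3-fold lower number from compound 2 to compound 4 (0.64 log units; beyond the scatter) on the same amide-type nitrogen, so an amine on the partner is not needed for a low number here. Against the methyl(phenyl)amino partner the gap reaches a 2800-fold lower number from compound 3 to compound 4 (3.44 log units; beyond the scatter) as the largest step in the set, leaving compound 4 with the lowest number of the four.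

No measurement shown gives a reason for these differences. Going by these compounds, whether a shorter acid partner such as carboxymethyl on the amide-type nitrogen, or the opposite stereocentres in the 1-carboxy-2-methylbutyl group, would keep the number this low stays open.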